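From pyridin-4-yl to 3,5-dimethyl-1,2-oxazol-4-yl on one carbon

A few compounds are considered here, and "the series" means these few. Any claim that something is new, unique, unknown or untested is made for them only; others in the source may bear on it.

- Compound 1 `CCc1c(C)[nH]c2cc(OCCCN3CCN(c4ccccc4)CC3)c(Cl)cc2c1=O`: > 23000 nM (a limit)
- Compound 2 `CCCCc1cc2c(=O)c(-c3ccncc3)c(C)[nH]c2cc1OCCOc1ccccc1`: 23000 nM
- Compound 3 `CCCCc1cc2c(=O)c(-c3ccc(Oc4ccc(OC(F)(F)F)cc4)cc3C)c(C)[nH]c2cc1OCCOc1ccccc1`: 16000 nM

In an ADME assay on J774 cells (Mus musculus) for antiproliferative activity, with a stated time of 72 h (a lower number here means that less compound is needed, a higher number that more compound is needed for the effect), compound 1 gives > 23000 nM, which is a limit and not a number. Compound 2 gives 23000 nM and compound 3 gives 16000 nM, and these two numbers lie within the usual scatter of each other. Among the compounds with values here, compound 2 therefore stands level with the only other true number.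

Compound 4 `CCCCc1cc2c(=O)c(-c3c(C)noc3C)c(C)[nH]c2cc1OCCOc1ccccc1` differs from compound 2 in one place: 3,5-dimethyl-1,2-oxazol-4-yl in place of pyridin-4-yl on an aromatic carbon. In words, 3,5-dimethyl-1,2-oxazol-4-yl stands in place of pyridin-4-yl on an aromatic carbon.

Within the data shown here, no two measured compounds differ in just one place, so this change has no direct precedent. Compound 3 carries a different group on that same carbon and gives 16000 nM, so no step beyond the scatter is expected in this assay. The estimated step is a 1.3-fold lower number from compound 2 to compound 4 (0.11 log units; within the scatter). For compound 4 the estimate is 18000 nM, with an expected range from 8000 nM to 32000 nM.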

Compound 4, half-maximal effective concentration: 22000 nM
Beside the measured number, compound 4's estimate is 1.2-fold (0.09 log units) below it; the range from low to high includes it.
By their numbers in this assay, from the lowest: compounds 3, 4 and 2 (each within the scatter of the next).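

Within the data shown here, putting 3,5-dimethyl-1,2-oxazol-4-yl in place of pyridin-4-yl, the first change in one place seen here, gives a 1.0-fold lower number from compound 2 to compound 4 (0.02 log units; within the scatter) in this assay. On this aromatic carbon, a five-membered aromatic ring with 2 hetero atoms can therefore replace a six-membered aromatic ring with 1 hetero atom without a step beyond the scatter. This pair sits close to the top of what the assay can report, so it says little about whether the change matters in a range where compounds need less to act, and one compound gives only a limit: the limit of > 23000 nM in this assay, at which 1 of the 4 values shown sits.

Going by these compounds, whether an amine or a carboxylic acid on this same carbon would give a step beyond the scatter remains open. On these data alone, the effect of a longer chain on this carbon also remains open.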